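Branched to Linear Amine Chain on the Amide Nitrogen

A few compounds are considered here, and "the series" means these few. Any claim that something is new, unique, unknown or untested is made for them only; others in the source may bear on it.

Three compounds sharing one core were measured in an ADME assay on Vero cells (Chlorocebus sabaeus) for cytotoxicity, read by neutral red uptake, with a stated time of 3 days; a lower number here means that less compound is tolerated, a higher number that more compound is tolerated. Compound 1 `CC(C)n1ncc2c(C(=O)NCCN3CCCC3)cc(C3CC3)nc21` gives 63100 nM and compound 3 `CC(C)n1ncc2c(C(=O)NC3CCN(C)C3)cc(C3CC3)nc21` gives 33800 nM, with the step of a 1.9-fold lower number from compound 1 to compound 3 (0.27 log units; within the scatter). For compound 2 `CC(CN(C)C)NC(=O)c1cc(C2CC2)nc2c1cnn2C(C)C` the assay reports only a limit, > 300000 nM, which is the limit of > 300000 nM in this assay, at which 1 of the 3 values shown sits. The steps of an at least 4.7-fold higher number from compound 1 to compound 2 (0.67 log units; beyond the scatter) and an at least 8.8-fold lower number from compound 2 to compound 3 (0.94 log units; beyond the scatter) place compound 2 as the best tolerated of the three. Compound 4 `CC(C)n1ncc2c(C(=O)NCCCN(C)C)cc(C3CC3)nc21` differs from compound 2 by 3-(dimethylamino)propyl in place of 1-((dimethylamino)methyl)ethyl on an amide-type nitrogen. Among the compounds with values here, no measured step turns a branched chain into a linear one, so the two steps around compound 2 are only a loose guide. A high number is expected for compound 4, estimated at 200000 nM with a range from 70000 nM to 300000 nM. The expected step is an at least 1.5-fold lower number from compound 2 to compound 4 (0.17 log units; that floor lies within the scatter).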

Compound 4, half-maximal cytotoxic concentration: > 200000 nM
Compound 4: a limit, no number; the forecaster's own chance of this, stated with the estimate: 40%; the middle value lies on the limit itself.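

Compound 4 gives only a limit, not a number: the limit of > 200000 nM in this assay, at which 1 of the 4 values shown sits.

The linear chain therefore keeps compound 4 clear of both amines carrying a pyrrolidine ring, with an at least 5.9-fold higher number from compound 3 to compound 4 (0.77 log units; beyond the scatter) and an at least 3.1-fold higher number from compound 1 to compound 4 (0.50 log units; beyond the scatter), so the branch of compound 2 is not needed for this high tolerance. Compound 2 and compound 4 both stand as limits, and the step between them cannot be read.

Any order between these two remains open, as does whether a longer chain ending in dimethylamino, or a diethylamino group at the chain end, would be tolerated as well.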